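A few compounds are considered here, and "the series" means these few. Any claim that something is new, unique, unknown or untested is made for them only; others in the source may bear on it.

Compound 1 `Cc1cc(=O)oc2cc(SCc3ccccn3)ccc12`, compound 2 `Cc1cc(=O)oc2cc(SCc3cccnc3)ccc12` and compound 3 `Cc1cc(=O)oc2cc(SCc3cccc(C(F)(F)F)c3)ccc12` were measured in a functional assay on A549 cells (Homo sapiens) for antiproliferative activity, read by sulforhodamine B assay, with a stated time of 72 h; on this read-out lower numbers stand for stronger inhibition of growth and higher numbers for weaker inhibition of growth. In this assay compound 1 gives > 35200 nM, which is a limit of the assay. Compound 2 gives > 35200 nM, also a limit. Compound 3 gives > 28500 nM, again a limit. Compound 3 therefore stands at the limit of > 28500 nM in this assay, at which 1 of the 3 values shown sits, and the other two values stand at the limit of > 35200 nM in this assay, at which 2 of the 3 values shown sit, so none of the three is a number. Within the data shown here, the only step between measured compounds, a step that the two limits leave unreadable from compound 1 to compound 2, gives no readable size.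

Compound 4 `COC(=O)c1cccc(CSc2ccc3c(C)cc(=O)oc3c2)c1` differs from compound 3 by methoxycarbonyl in place of trifluoromethyl on an aromatic carbon. Among the measured compounds shown here, no measured step bears on this change, and with all three values at limits no direction can be read. Compound 4 is therefore expected to sit close to the limits as well, with an estimated value of 40000 nM, within 12000 nM to 120000 nM, which would mean an expected step that the limit leaves unreadable from compound 3 to compound 4.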

Compound 4, concentration for 50% growth inhibition: 7700 nM
Compound 4: middle estimate off by 5.2-fold (0.72 log units), on the high side; the measured number lies below the stated range.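

In this assay, methoxycarbonyl in place of trifluoromethyl on this aromatic carbon gives an at least 3.7-fold lower number from compound 3 to compound 4 (0.56 log units; beyond the scatter). Among these compounds, compound 4 is thus the first compound here with a readable number, which shows that a change at this carbon alone can bring growth inhibition within the measurable range. Compound 3 is only a limit, so this step gives a minimum size and not an exact one: the limit of > 28500 nM in this assay, at which 1 of the 4 values shown sits.

The compounds shown leave open whether a carboxylic acid or an amide on this carbon would keep the lower number. They also leave open whether methoxycarbonyl on another carbon of this ring would do the same.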